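Configuration change at a saturated ring carbon

This account rests on a few compounds, and the source may have more. Where it says the series, first, only, none or still open, it means among the compounds named here.

Measured compounds:
compound 1 `COc1cc([C@H]2C[C@@]2(CO)C(=O)NCc2ccc(C)cc2)cc(OC)c1OC` — > 100000 nM
compound 2 `CCOC(=O)[C@@]1(C(=O)NCc2ccc(C)cc2)C[C@@H]1c1cc(OC)c(OC)c(OC)c1` — > 100000 nM

In a functional assay on QGY cells (Homo sapiens) for cytotoxicity, read by MTT assay, with a stated time of 48 h (on this read-out higher numbers stand for weaker inhibition and lower numbers for stronger inhibition), compound 1 gives > 100000 nM, which is a limit of the assay rather than a number. Compound 2 in this assay gives > 100000 nM, likewise a limit. The only measured step, a step that the two limits leave unreadable from compound 1 to compound 2, is therefore unreadable in size, and the whole of the shown evidence is the limit of > 100000 nM in this assay, at which 2 of the 2 values shown sit.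

Compound 3 `COc1cc([C@@H]2C[C@@]2(CO)C(=O)NCc2ccc(C)cc2)cc(OC)c1OC` is the next member: the two compounds have the same atoms and bonds and differ only in configuration as drawn: 1 of 2 stereo elements differ; a stereocentre at a saturated ring carbon is drawn R in compound 1 and S in compound 3. Going by the values given here, no measured step involves a change of configuration, so none bears directly on it; the only guidance is that every value shown in this assay sits at the limit. On that basis compound 3 is expected to be reported in this assay around 150000 nM, within 50000 nM to 500000 nM, most probably again as a limit. The expected step is a step that the limit leaves unreadable from compound 1 to compound 3, that is, none beyond the scatter.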

Compound 3, half-maximal inhibitory concentration: 58700 nM
Beside the measured number, compound 3's estimate is 2.6-fold (0.41 log units) above it, within the range that was stated.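

In this assay, going by these compounds alone, compound 3 gives 58700 nM, the first actual number. The earlier compounds shown here showed only limits. Inverting the stereocentre at the saturated ring carbon gives an at least 1.7-fold lower number from compound 1 to compound 3 (0.23 log units; that floor lies within the scatter), so configuration at this carbon is enough to move the read-out off the limit, though the true size of the step stays unknown. The comparison isolates this single stereocentre, with no other structural change involved: the fact that compounds 1 and 3 differ only in the configuration as drawn

As far as these compounds go, it remains open whether ethoxycarbonyl, a carboxylic acid or a primary amine in place of hydroxymethyl on the saturated ring carbon would give a number with the configuration of compound 3. From the compounds shown here alone, the effect of inverting the second stereo element also remains open.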